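Adding a Fluorine on Two Related Cores

A few compounds are considered here, and "the series" means these few. Any claim that something is new, unique, unknown or untested is made for them only; others in the source may bear on it.

The measured compounds:

Compound 1, `O=C1C(Nc2ccc(F)cc2)=CC(=O)c2ncccc21`, gives 541 nM in a functional assay (aorta) for inhibition, with Rattus norvegicus as the target; on this read-out lower numbers stand for an effect already at smaller amounts and higher numbers for an effect only at larger amounts of compound.
Compound 2, `O=C1C(Nc2ccc(F)c(F)c2)=CC(=O)c2ncccc21`, gives 251 nM.
Compound 3, `O=C1C=C(Nc2ccccc2)C(=O)c2cnccc21`, gives 439 nM.

Compound 1 and compound 2 differ in one place: fluoro in place of hydrogen on an aromatic carbon. That change gave a 2.2-fold lower number from compound 1 to compound 2 (0.33 log units; beyond the scatter), so the second fluorine went with an effect at smaller amounts of compound.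

Compound 3 carries a different core, and the difference between the two cores is not broken down here; its value and that of compound 1 lie within the scatter of each other, so nothing can be said about an order between them.

Compound 4, `O=C1C=C(Nc2ccc(F)cc2)C(=O)c2cnccc21`, has not yet been measured. It relates to compound 3 as compound 2 relates to compound 1: fluoro in place of hydrogen on an aromatic carbon. This is the same kind of change, but not the same one, since the surroundings of the new fluorine differ. In compound 2 the fluorine sits ortho to a fluoro group and meta to a large group, whereas in compound 4 it sits para to a large group, with no other fluorine on that ring.

Going by the values given here, on the strength of the single earlier step, the expected move from compound 3 to compound 4 is a 1.5-fold lower number from compound 3 to compound 4 (0.18 log units; within the scatter), which rests on the step of a 2.2-fold lower number from compound 1 to compound 2 (0.33 log units; beyond the scatter) seen on the other core. Among the compounds with values here, compound 4 is therefore estimated at 290 nM, with a range from 130 nM to 650 nM, kept wide because only one step of this kind is known.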

Compound 4, half-maximal effective concentration: 1230 nM
The estimate for compound 4 lay 4.2-fold (0.63 log units) below the measured number; measured number outside the range, above it.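

In this assay, putting fluoro in place of hydrogen on the aromatic ring, para to a large group, gave a 2.8-fold higher number from compound 3 to compound 4 (0.45 log units; beyond the scatter), meaning that compound 4 needs larger amounts of compound for the same effect. The same kind of change therefore did not carry over from one core to the other, and the two steps ran in opposite directions: the same change on two cores in this assay, a 2.2-fold lower number (0.33 log units; beyond the scatter) from compound 1 to compound 2 and a 2.8-fold higher number (0.45 log units; beyond the scatter) from compound 3 to compound 4, 6.0-fold (0.78 log units) apart, beyond the scatter of two such steps. This does not show what sets the two steps apart, since the cores differ and so does the setting of the new fluorine, which joins a ring already bearing a fluoro group in compound 1 but a ring with no other fluorine in compound 3, and a single step on each core gives no rule for either core.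

The compounds shown leave open how this step would read if the core changed while the ring and the place of the new fluorine stayed the same. They also leave open whether a chloro or a methoxy group in that same place would move the number in the same direction as fluoro on each core, or whether the split between the two cores is particular to fluoro.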